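The compounds below may be only part of what the source reports. "The series", "measured", "known", "first", "only" and "open" are said of these compounds alone.

Of the compounds shown here, three have so far been measured in a functional assay on KOPN-8 cells (Homo sapiens) for antiproliferative activity, with a stated time of 72 h; a higher number here means that more compound is needed for the effect, a lower number that less compound is needed. Compound 1 `COc1cc(OC)c2c(=O)cc(C(=O)Nc3ccc(Oc4ccc([N+](=O)[O-])cc4)cc3)[nH]c2c1` gives 20500 nM. Compound 2 `COC(=O)c1cc(=O)c2cc(NC(=O)Nc3ccc(Cl)c(Cl)c3)ccc2[nH]1` reaches only a limit of the assay, > 6350 nM. Compound 3 `COC(=O)c1cc(=O)c2cc(NC(=O)Nc3ccc(F)c(Cl)c3)ccc2[nH]1` likewise reaches only a limit, > 6350 nM. The step that the two limits leave unreadable from compound 2 to compound 3 therefore cannot be read, since (the limit of > 6350 nM in this assay, at which 2 of the 3 values shown sit). Compound 4 `COC(=O)c1cc(=O)c2cc(NC(=O)Nc3cccc(C(C)=O)c3)ccc2[nH]1` carries the change (3-acetylphenyl in place of 3-chloro-4-fluorophenyl on an amide-type nitrogen). Going by the values given here, no measured step bears directly on this change: the one step between compounds 2 and 3 is unreadable, and compound 1 rests on a different core. Compound 4 is therefore expected to remain in the same weak region, most likely again at the limit, with an estimated 9000 nM spanning 2500 nM to 30000 nM. The step that the limit leaves unreadable from compound 3 to compound 4 is expected to be none beyond the scatter.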

Compound 4, half-maximal effective concentration: > 8080 nM
Compound 4: no number, only a limit; the forecaster's own chance of this, stated with the estimate: 60%; the middle value lies beyond the limit too.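

Compound 4 gives only a limit, > 8080 nM, and its steps from compound 2 and compound 3 cannot be read. From the compounds shown here alone, how compound 2, compound 3 and compound 4 truly compare in this assay stays open.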